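This account rests on a few compounds, and the source may have more. Where it says the series, first, only, none or still open, it means among the compounds named here.

Working notes on the series measured in a functional assay on SH-SY5Y cells (Homo sapiens), read by MTT assay, with a stated time of 24 h; a higher number here means that more compound is needed for the effect, a lower number that less compound is needed. Compound 1 `COc1ccc(Cl)cc1N(CC(=O)Nc1ccc(C(F)(F)F)cc1)S(=O)(=O)c1ccccc1` gives 3750 nM. Compound 2 `COc1ccc(Cl)cc1N(CC(=O)Nc1ccc(Cl)cc1)S(=O)(=O)c1ccccc1` reaches only the limit of the assay, > 20000 nM; this is a limit and not a number, as recorded in the limit of > 20000 nM in this assay, at which 1 of the 3 values shown sits. Compound 3 `COc1cccc(NC(=O)CN(c2cc(Cl)ccc2OC)S(=O)(=O)c2ccccc2)c1` gives 17600 nM, the highest of the two numbers shown; its nearest neighbour is compound 1, with a 4.7-fold higher number from compound 1 to compound 3 (0.67 log units; beyond the scatter). Compound 2 and compound 3 stand within the scatter of one another, as an at least 1.1-fold lower number from compound 2 to compound 3 (0.05 log units; that floor lies within the scatter) shows.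

Compound 4 `COc1ccc(Cl)cc1NC(=O)CN(c1cc(Cl)ccc1OC)S(=O)(=O)c1ccccc1` differs from compound 3 by 5-chloro-2-methoxyphenyl in place of 3-methoxyphenyl on an amide-type nitrogen. Among the compounds with values here, two measured steps bear on the aryl group on the amide-type nitrogen: a 4.7-fold higher number from compound 1 to compound 3 (0.67 log units; beyond the scatter), a modest step, and an at least 1.1-fold lower number from compound 2 to compound 3 (0.05 log units; that floor lies within the scatter), which lay within the scatter. Within the data shown here, neither step tests the 5-chloro-2-methoxyphenyl group itself, and the one chloro-bearing aryl group on the amide-type nitrogen, in compound 2, returned a limit. The change into compound 4 is therefore expected to give a small step or an upward one, a 1.3-fold higher number from compound 3 to compound 4 (0.10 log units; within the scatter), with a real chance that only a limit is reported. The estimate for compound 4 in this assay is 22000 nM, with a range of 8000 nM to 60000 nM.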

Compound 4, half-maximal effective concentration: > 20000 nM
Compound 4: only a limit was reported; the forecaster's own chance of this, stated with the estimate: 45%; the middle value is on the limit's open side.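

Compound 4 is a limit of the assay and not a number, which places a second chloro-bearing aryl group on the amide-type nitrogen at that limit in this assay: the limit of > 20000 nM in this assay, at which 2 of the 4 values shown sit.

Adding the chlorine-bearing 5-chloro-2-methoxyphenyl group in place of 4-(trifluoromethyl)phenyl gives an at least 5.3-fold higher number from compound 1 to compound 4 (0.72 log units; beyond the scatter), so compound 1 now stands beyond the scatter from all three other compounds, and among these four aryl groups only 4-(trifluoromethyl)phenyl gives a clearly lower number. Replacing 3-methoxyphenyl gives an at least 1.1-fold higher number from compound 3 to compound 4 (0.05 log units; that floor lies within the scatter), which shows no readable gain or loss at this position, and the step between the two limits cannot be read.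

Going by these compounds, how far compound 2 and compound 4 lie past the limit remains unknown, so the aryl groups at that end of the series cannot be ranked against one another. On these data alone, it also remains open whether the lower number of compound 1 depends on trifluoromethyl itself or would persist with another group on that aryl ring, such as a nitrile or a carboxylic acid.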